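A Bromoacrylamide Series Tested for Cytotoxicity in Mouse Cells

A few compounds are considered here, and "the series" means these few. Any claim that something is new, unique, unknown or untested is made for them only; others in the source may bear on it.

Measured compounds:
compound 1 `C=C(Br)C(=O)Nc1ccc(/C=C2\SC(=O)N(CC)C2=O)cc1`: 2300 nM
compound 2 `CC(C)(C)c1ccc(CN2C(=O)S/C(=C\c3ccc(N)cc3)C2=O)cc1`: 80000 nM
compound 3 `C=C(Br)C(=O)Nc1cccc(/C=C2\SC(=O)N(Cc3ccc(C)cc3)C2=O)c1`: 1000 nM

In a functional assay on FM3A cells (Mus musculus) for cytotoxicity, read by cell counting, with a stated time of 2 days (on this read-out higher numbers stand for weaker inhibition and lower numbers for stronger inhibition), compound 1 gives 2300 nM, the second highest of the three numbers. Compound 3 gives 1000 nM, a lower number, and compound 2 gives 80000 nM, a far higher one; both gaps lie beyond the usual scatter. Compound 4 `C=C(Br)C(=O)Nc1ccc(/C=C2\SC(=O)N(Cc3cccc(Cl)c3)C2=O)cc1` has not yet been measured. It differs from compound 1 in a single place: 3-chlorophenyl in place of methyl on a saturated chain carbon bound to an amide-type nitrogen in a ring. For the measured compounds named here, no pair of measured compounds isolates this change, so its effect is not known. Since compound 3 gives 1000 nM, a modest step toward lower numbers is expected, though it may fall within the scatter. Compound 4 is expected to give 1500 nM, with a range from 500 nM to 5000 nM, an expected step of a 1.5-fold lower number from compound 1 to compound 4 (0.19 log units; within the scatter).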

Compound 4, half-maximal inhibitory concentration: 6100 nM
Compound 4: middle estimate off by 4.1-fold (0.61 log units), on the low side; measured number above the stated range.
By their numbers in this assay, from the lowest: compound 3; then compound 1; then compound 4; then compound 2.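

In this assay, replacing methyl with 3-chlorophenyl, which amounts to exchanging ethyl for 3-chlorobenzyl, gives a 2.7-fold higher number from compound 1 to compound 4 (0.42 log units; beyond the scatter). This first isolated change at this position shows that the position responds, and that here adding this aromatic ring brings weaker inhibition rather than stronger. Nothing available explains why the step goes in this direction.

As far as these compounds go, whether plain benzyl, without the chlorine, would behave like 3-chlorobenzyl remains open. So does the effect of a longer chain, such as butyl, or of a carboxylic acid at this position.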